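This account rests on a few compounds, and the source may have more. Where it says the series, first, only, none or still open, it means among the compounds named here.

Compound 1 `O=C(Nc1cccc(CNc2nccnc2Cl)c1)Nc1ccccc1F` gives 6440 nM in a functional assay on MGC-803 cells (Homo sapiens) for antiproliferative activity, read by MTT assay, with a stated time of 48 h; a higher number here means a weaker inhibitor, a lower number a stronger inhibitor.
Compound 2 `CC(C)(C)c1ccc(NC(=O)Nc2cccc(CNc3nccnc3Cl)c2)cc1` gives 4820 nM in this assay.
Compound 3 `Cc1ccc(NC(=O)Nc2cccc(CNc3nccnc3Cl)c2)c(C)c1` gives 10100 nM in this assay.

Compound 3 carries the highest of these three numbers: compound 1 stands nearest, and compound 2 stands lowest, beyond the scatter from compound 3. Compound 4 `CN(C)c1ccc(NC(=O)Nc2cccc(CNc3nccnc3Cl)c2)cc1` differs from compound 3 in one place: 4-(dimethylamino)phenyl in place of 2,4-dimethylphenyl on an amide-type nitrogen. Among the compounds with values here, the only measured single change on this same amide-type nitrogen, a 1.6-fold higher number from compound 1 to compound 3 (0.20 log units; within the scatter), lies within the scatter, so swapping one aryl group for another here has so far moved this assay little. For compound 4 the step of a 1.4-fold lower number from compound 3 to compound 4 (0.16 log units; within the scatter) is therefore expected to stay within the scatter. Compound 4 is estimated at 7000 nM, with a range from 3000 nM to 17000 nM.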

Compound 4, half-maximal inhibitory concentration: 11500 nM
The estimate for compound 4 lay 1.6-fold (0.22 log units) below the measured number; measured number inside the range.
By their numbers in this assay, from the lowest: compounds 2, 1, 3 and 4 (each within the scatter of the next, the first and the last beyond it).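

At the amide-type nitrogen, 4-(dimethylamino)phenyl reads no differently from 2,4-dimethylphenyl (a 1.1-fold higher number from compound 3 to compound 4 (0.06 log units; within the scatter)) or 2-fluorophenyl (a 1.8-fold higher number from compound 1 to compound 4 (0.25 log units; within the scatter)). Dimethylamino in place of tert-butyl on an aromatic carbon does move the number, though modestly (a 2.4-fold higher number from compound 2 to compound 4 (0.38 log units; beyond the scatter)), so this is the one change involving compound 4 that exceeds the scatter. No measurement here explains that difference.

Still open, going by these compounds, is whether a carboxylic acid or a morpholine on that aromatic carbon would shift the number further. Also open, on these data alone, is whether a longer chain in place of tert-butyl would do so.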